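Solubility of Three Compounds and an Expected Fourth

A few compounds are considered here, and "the series" means these few. Any claim that something is new, unique, unknown or untested is made for them only; others in the source may bear on it.

The study follows three compounds built on a shared core and differing in a single group on the outer ring. Compound 1 `Cc1cc(NC(=O)Nc2cccc(Cl)c2)c2ccccc2n1` in a physicochemical assay for solubility, at pH 7.4 (a lower number here means a less soluble compound, a higher number a more soluble compound), gives 800 nM. Compound 2 `COC(=O)c1cccc(NC(=O)Nc2cc(C)nc3ccccc23)c1` gives 600 nM, and compound 3 `Cc1cc(NC(=O)Nc2cccc(OC(F)(F)F)c2)c2ccccc2n1` gives 600 nM. The three numbers sit close together: a 1.3-fold lower number from compound 1 to compound 2 (0.12 log units; within the scatter), a 1.3-fold lower number from compound 1 to compound 3 (0.12 log units; within the scatter) and no change at the digits printed from compound 2 to compound 3 (within the scatter). Compound 3 thus stands level with compound 2 at the digits shown, the two together being the lowest of the three numbers, with compound 1 the furthest from it by a margin that still lies inside the scatter.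

The next compound, compound 4 `Cc1cc(NC(=O)Nc2cccc(C(C)(C)C)c2)c2ccccc2n1`, differs from compound 3 in one place: tert-butyl in place of trifluoromethoxy on an aromatic carbon. Among the measured compounds shown here, no measured step involves a tert-butyl group, so none bears on this change directly. What the three measured steps do show is that exchanging the group among chloro, methoxycarbonyl and trifluoromethoxy left the number unmoved beyond the scatter. On that basis the expected step is a 1.2-fold lower number from compound 3 to compound 4 (0.08 log units; within the scatter), that is, no movement beyond the scatter, with a slight lean toward a lower number. Compound 4 is therefore estimated at 500 nM in this assay, with a range from 200 nM to 1500 nM.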

Compound 4, solubility: 34700 nM
Estimate against measurement, compound 4: 69-fold (1.84 log units) below; measured number above the stated range.
By their numbers in this assay, from the lowest: compounds 2, 3 and 1 (each within the scatter of the next); then compound 4.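

At this position on the outer ring, the exchanges among chloro, methoxycarbonyl and trifluoromethoxy had moved nothing beyond the scatter, yet tert-butyl produces a 58-fold higher number from compound 3 to compound 4 (1.76 log units; beyond the scatter) and a 58-fold higher number from compound 2 to compound 4 (1.76 log units; beyond the scatter) and a 43-fold higher number from compound 1 to compound 4 (1.64 log units; beyond the scatter) in this series. Among the compounds shown here, the position is therefore far from indifferent in this assay as the earlier compounds had suggested: all three steps are large and point the same way whichever group leaves, so that compound 4 stands apart from the other three while they remain within the scatter of one another. The change swaps trifluoromethoxy, with its oxygen, three fluorine atoms and one hydrogen-bond acceptor, for tert-butyl, with four carbon atoms and no hydrogen-bond acceptor, but no measurement at hand accounts for the size of the step.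

The rise rests on a single compound, so the compounds shown leave open whether it belongs to tert-butyl alone or would extend to other groups at this position, such as isopropyl, cyclopropyl, a longer alkyl chain or an amine. They also leave open whether tert-butyl would give a similar step at another carbon of the same ring or on a different core.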